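Cytotoxicity of a dichlorophenyl analogue in liver cells

The source may report more compounds than this note shows. Statements on the series, on what has been measured and on what is new or still open speak of the compounds shown alone.

Compound 2 `CC(C)N(Cc1cccc(OCCCCCC(=O)O)c1)C(=O)c1ccc(-c2cccc(Br)c2)cc1` carries a 3-bromophenyl group on the shared core. In an ADME assay on HepG2 cells (Homo sapiens) for cytotoxicity, read by CellTiter-Glo and resazurin assay, with a stated time of 72 h (a higher number here means that more compound is needed for the effect, a lower number that less compound is needed), compound 2 gives > 26000 nM, which is a limit of the assay rather than a number. Compound 1 `CC(C)N(Cc1cccc(OCCCCCC(=O)O)c1)C(=O)c1ccc(-c2ccco2)cc1` bears furan-2-yl on the same core. In this assay compound 1 gives > 26000 nM, again a limit. The step that the two limits leave unreadable from compound 1 to compound 2 therefore cannot be read. What the measurements offer is the limit of > 26000 nM in this assay, at which 2 of the 2 values shown sit.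

Compound 3 `CC(C)N(Cc1cccc(OCCCCCC(=O)O)c1)C(=O)c1ccc(-c2ccc(Cl)c(Cl)c2)cc1` differs from compound 2 by 3,4-dichlorophenyl in place of 3-bromophenyl on an aromatic carbon. For the measured compounds named here, the only measured step that touches this part of the molecule is the unreadable one from compound 1 to compound 2, so no measured size is available to set the size of the new step, in either direction. With no readable step and no number to move from, compound 3 is expected to remain at the limit, meaning an expected step that the limit leaves unreadable from compound 2 to compound 3. For compound 3 the estimate in this assay is 30000 nM, with a range from 15000 nM to 80000 nM.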

Compound 3, half-maximal effective concentration: > 26000 nM
Compound 3: no number, only a limit (the forecaster's own chance of this, stated with the estimate: 85%); the middle value is on the limit's open side.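

In this assay compound 3 gives > 26000 nM, again a limit and not a number, so no step among compound 1, compound 2 and compound 3 can be read: the limit of > 26000 nM in this assay, at which 3 of the 3 values shown sit.

The compounds shown leave open whether furan-2-yl, 3-bromophenyl and 3,4-dichlorophenyl on the shared core differ at all in this assay.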